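Swapping the Ring Nitrogen Methyl for Isopropyl

A few compounds are considered here, and "the series" means these few. Any claim that something is new, unique, unknown or untested is made for them only; others in the source may bear on it.

Compound 1 `CN1C(=O)C=C(Cl)C1(O)c1ccccc1` was tested in an assay on cell membranes for displacement of a labelled ligand from Cholecystokinin receptor type A (Rattus norvegicus), read by CCK-8 assay, with a stated time of 2 h (a higher number here means a weaker inhibitor, a lower number a stronger inhibitor), where compound 1 gives 2500 nM. Within the data shown here, only one other number sits beside it: compound 2 `CN1C(=O)C=C(Cl)C1(O)c1ccc(Cl)cc1`, which in this assay gives 2000 nM, and the two values lie within the scatter of each other. Among the measured compounds shown here, the single measured step, a 1.3-fold lower number from compound 1 to compound 2 (0.10 log units; within the scatter), concerns chloro in place of hydrogen on an aromatic carbon and does not rise above the noise of repeat measurements.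

The unmeasured compound 3 `CC(C)N1C(=O)C=C(Cl)C1(O)c1ccccc1` departs from compound 1 at a different place: isopropyl in place of methyl on an amide-type nitrogen in a ring. For the measured compounds named here, no measured step touches this nitrogen substituent, so the only comparison in hand bears on it merely as a sign that one small change to this core left the number where it was. On that basis no shift beyond the scatter is expected, and the expected step is no change at the digits printed from compound 1 to compound 3 (within the scatter). Compound 3 is therefore estimated to give 2500 nM in this assay, with a range from 800 nM to 8000 nM.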

Compound 3, half-maximal inhibitory concentration: 200 nM
Compound 3: the middle estimate sits 13-fold (1.10 log units) above what was measured; measured number outside the range, below it.
By their numbers in this assay, from the lowest: compound 3; then compounds 2 and 1 (each within the scatter of the next).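

In this assay, the substituent on the amide-type nitrogen proved far more consequential than the aromatic carbon change seen earlier: isopropyl in place of methyl gives a 13-fold lower number from compound 1 to compound 3 (1.10 log units; beyond the scatter), a large step beyond the scatter, whereas chloro in place of hydrogen gives only a 1.3-fold lower number from compound 1 to compound 2 (0.10 log units; within the scatter). This step is made by carbon alone, as methyl with 1 heavy atom gives way to isopropyl with 3 heavy atoms, and neither group has a ring, a hydrogen-bond donor or acceptor, or a net charge. Nothing available explains why this swap moves the number so strongly.

From the compounds shown here alone, it remains open whether the number would keep falling or turn back up with cyclopropyl, tert-butyl, benzyl or a longer chain such as n-butyl on this nitrogen, and what an amine or a carboxylic acid at the end of such a chain would do. Among these compounds, also unresolved is whether chloro on the aromatic carbon would change the number once isopropyl sits on the nitrogen, since its step has been seen only with methyl there.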